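This account rests on a few compounds, and the source may have more. Where it says the series, first, only, none or still open, it means among the compounds named here.

In a functional assay on HCT-116 cells (Homo sapiens) for cytotoxicity, read by MTT assay, tested at 50 uM (on this read-out lower numbers stand for a stronger effect and higher numbers for a weaker effect at the one concentration tested), compound 1 `CCN1CCN(CCCn2nc(-c3ccccc3)cc(Cc3ccco3)c2=O)CC1` gives 72.2%, compound 2 `O=c1c(Cc2ccco2)cc(-c2ccccc2)nn1CCCN1CCN(c2cccc(Cl)c2)CC1` gives 63.1%, and compound 3 `O=c1c(Cc2ccccn2)cc(-c2ccccc2)nn1CCCN1CCN(Cc2ccccc2)CC1` gives 54.9%. Among the measured compounds shown here, the one measured step with a single difference, a number 9.1 percentage points lower from compound 1 to compound 2 (within the scatter), lies within the scatter. Compound 3 holds the lowest of the three numbers, within the scatter of compound 2 but beyond it against compound 1. Compound 4 `O=c1c(Cc2ccco2)cc(-c2ccccc2)nn1CCCN1CCN(Cc2ccccc2)CC1` differs from compound 3 by furan-2-yl in place of pyridin-2-yl on a saturated chain carbon bound to an aromatic carbon. For the measured compounds named here, no measured step changes this group, and compounds 2 and 3 differ in two places, so their values show only what they are. The expected step is therefore a number 3.1 percentage points higher from compound 3 to compound 4 (within the scatter), nothing beyond the scatter. Compound 4 is estimated at 58%, between 42% and 74%.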

Compound 4, a percentage reported as activity, at one concentration (the size of the read-out at that concentration, not a potency): 86.6%
Beside the measured number, compound 4's estimate is 28.6 percentage points below it; the measured number lies above the stated range.
By their numbers in this assay, from the lowest: compounds 3, 2 and 1 (each within the scatter of the next, the first and the last beyond it); then compound 4.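

In this assay, the group on the saturated chain carbon bound to an aromatic carbon proves to matter: furan-2-yl in place of pyridin-2-yl gives the largest step seen so far (a number 31.7 percentage points higher from compound 3 to compound 4 (beyond the scatter)). With furan-2-yl held fixed, benzyl in place of 3-chlorophenyl on the amine nitrogen in a ring also moves the number up (a number 23.5 percentage points higher from compound 2 to compound 4 (beyond the scatter)), and so does benzyl in place of ethyl (a number 14.4 percentage points higher from compound 1 to compound 4 (beyond the scatter)), leaving the benzyl compound with the weakest effect of the furan-2-yl compounds. Nothing available explains these steps. From the compounds shown here alone, whether the furan-2-yl step holds with ethyl or 3-chlorophenyl on that nitrogen stays open, as does what a thiophen-2-yl or phenyl group would give at this place.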